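A Halogen Swap Carried Over to a Second Core

The source may hold more compounds than are shown below. What is called first, only, known or untested is meant among the compounds shown, and "the series" means these compounds.

Compound 1 `CNc1nc(-c2ccccc2)nc2c1nnn2Cc1ccccc1Cl` is the reference point of this small set. In an assay on Cerebral cortex for displacement of a labelled ligand from adenosine receptor A1 (Bos taurus) (a lower number here means a stronger inhibitor, a higher number a weaker inhibitor), compound 1 gives 191 nM. Compound 2 `CNc1nc(-c2ccccc2)nc2c1nnn2Cc1ccccc1F` differs from it by fluoro in place of chloro on an aromatic carbon, and in this assay compound 2 gives 25 nM, so that a 7.6-fold lower number from compound 1 to compound 2 (0.88 log units; beyond the scatter). Compound 3 `CCNc1nc(-c2ccccc2)nc2c1nnn2Cc1ccccc1Cl` differs from compound 1 in its core by methyl in place of hydrogen on a saturated chain carbon bound to a nitrogen on an aromatic ring, and in this assay compound 3 gives 463 nM, which means a 2.4-fold higher number from compound 1 to compound 3 (0.38 log units; beyond the scatter); among the three measured compounds it has the highest number. Compound 4 `CCNc1nc(-c2ccccc2)nc2c1nnn2Cc1ccccc1F` has not yet been measured. It differs from compound 3 by fluoro in place of chloro on an aromatic carbon, the same change as that between compound 1 and compound 2, now made on the core of compound 3. Should the change behave as it did before, compound 4 is expected to show a 7.1-fold lower number from compound 3 to compound 4 (0.85 log units; beyond the scatter), a step of about the size recorded as a 7.6-fold lower number from compound 1 to compound 2 (0.88 log units; beyond the scatter), an expectation that rests on that single earlier pair alone. Compound 4 is therefore estimated at 65 nM in this assay, with a range from 25 nM to 200 nM expected.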

Compound 4, inhibition constant: 11 nM
Beside the measured number, compound 4's estimate is 5.9-fold (0.77 log units) above it, and the stated range ends above it.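

In this assay, fluoro in place of chloro lowers the number on both cores, but the size does not carry over, with a 42-fold lower number from compound 3 to compound 4 (1.62 log units; beyond the scatter) standing well apart from the earlier step: the same change on two cores in this assay, a 7.6-fold lower number (0.88 log units; beyond the scatter) from compound 1 to compound 2 and a 42-fold lower number (1.62 log units; beyond the scatter) from compound 3 to compound 4, 5.5-fold (0.74 log units) apart, beyond the scatter of two such steps The added methyl likewise depends on the halogen present, and with fluoro the result is a 2.3-fold lower number from compound 2 to compound 4 (0.36 log units; beyond the scatter), opposite in direction to the step seen with chloro: the same change on two cores in this assay, a 2.4-fold higher number (0.38 log units; beyond the scatter) from compound 1 to compound 3 and a 2.3-fold lower number (0.36 log units; beyond the scatter) from compound 2 to compound 4, 5.5-fold (0.74 log units) apart, beyond the scatter of two such steps Across these four compounds, the direction of the halogen swap carries from one core to the other while its size does not, and the data show neither why the two changes interact nor whether the same holds for any other pair of cores.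

Going by these compounds, how a bromo group or a methoxy group in place of the halogen would behave remains open. So does whether a longer chain such as propyl on the amine nitrogen would widen or narrow the gap between the fluoro and chloro compounds.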